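Removing a Fluorine From the Aryl Ring

The compounds below may be only part of what the source reports. "The series", "measured", "known", "first", "only" and "open" are said of these compounds alone.

Compound 2 `O=C(COc1ccc(C(=O)/C=C/c2cccc(F)c2)cc1)N[C@H]1CCOC1=O` gives 17200 nM in a functional assay on DU-145 cells (Homo sapiens) for antiproliferative activity, read by MTT assay, with a stated time of 72 h; a lower number here means a stronger inhibitor, a higher number a weaker inhibitor. Of the two compounds measured, compound 2 has the higher number, though compound 1 `CC(C)c1ccc(/C=C/C(=O)c2ccc(OCC(=O)N[C@H]3CCOC3=O)cc2)cc1` sits within the scatter of it at 13100 nM in this assay. Compound 3 `O=C(COc1ccc(C(=O)/C=C/c2ccccc2)cc1)N[C@H]1CCOC1=O` differs from compound 2 by hydrogen in place of fluoro on an aromatic carbon. Within the data shown here, the single measured step, a 1.3-fold higher number from compound 1 to compound 2 (0.12 log units; within the scatter), exchanged the whole aryl group and stayed within the scatter, so a smaller change on that same ring is expected to move the number little, if at all. Compound 3 is therefore estimated at 15000 nM, between 7000 nM and 35000 nM, with an expected step of a 1.1-fold lower number from compound 2 to compound 3 (0.06 log units; within the scatter).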

Compound 3, half-maximal inhibitory concentration: 48300 nM
Compound 3: middle estimate off by 3.2-fold (0.51 log units), on the low side, and the stated range ends below it.
By their numbers in this assay, from the lowest: compounds 1 and 2 (each within the scatter of the next); then compound 3.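

In this assay the substituent on this ring does matter: hydrogen in place of fluoro gives a weaker compound (a 2.8-fold higher number from compound 2 to compound 3 (0.45 log units; beyond the scatter)), and hydrogen in place of isopropyl does too (a 3.7-fold higher number from compound 1 to compound 3 (0.57 log units; beyond the scatter)). The phenyl ring of compound 3 thus stands apart from the 3-fluorophenyl and 4-isopropylphenyl rings, which remain within the scatter of each other. Nothing available here explains this difference. Still open, on these data alone, is whether other groups on this ring, such as methoxy or an amine, would match fluoro and isopropyl, and whether fluoro elsewhere on the ring would do the same.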